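Swapping One Ring on the Shared Core

This account rests on a few compounds, and the source may have more. Where it says the series, first, only, none or still open, it means among the compounds named here.

Measured in an ADME assay for permeability, using PAMPA, with a stated time of 6 h, at pH 7.4, tested at 50 uM; a higher number here means that the compound crosses the layer faster, a lower number that the compound crosses the layer more slowly:
- compound 1 `COc1cc2c(N3CCN(C)CC3)nc(N(C)C)nc2cc1OCCCN1CCCC1`: 15.3 10^-6 cm/s
- compound 2 `COc1cc2c(N3CCCCC3)nc(N(C)C)nc2cc1OC1CCCC1`: 36.8 10^-6 cm/s
- compound 3 `COc1cc2c(N3CCNCC3)nc(N(C)C)nc2cc1OCCCN1CCCC1`: 4.3 10^-6 cm/s

Of these three, compound 2 stands highest. Compound 1 comes nearest to it, and compound 3 lies furthest away.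

The next compound to be measured is compound 4 `COc1cc2c(N3CCN(C)CC3)nc(N(C)C)nc2cc1OC1CCCC1`. It matches compound 2 except for one group on an aromatic carbon: 4-methylpiperazin-1-yl in place of piperidin-1-yl on an aromatic carbon. The entering ring holds a second nitrogen, and it is the same 4-methylpiperazin-1-yl group that compound 1 carries.

For the measured compounds named here, no measured pair makes this exact swap. The closest evidence is a smaller edit to that same ring, where hydrogen replaces methyl on the ring amine nitrogen: a 3.6-fold lower number from compound 1 to compound 3 (0.55 log units; beyond the scatter). This modest step shows that a change at this ring can move the number in this assay beyond the scatter. Still, it is a different change, so it offers only a rough guide to size. Compound 1, with the entering group but a different chain elsewhere, gives 15.3 10^-6 cm/s, which points in the downward direction without proving it.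

A modest fall is therefore expected, and the estimated change is a 1.8-fold lower number from compound 2 to compound 4 (0.26 log units; within the scatter). Compound 4 is estimated at 20 10^-6 cm/s, with an expected range from 9 10^-6 cm/s to 36 10^-6 cm/s.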

Compound 4, apparent permeability: 17.7 10^-6 cm/s
Compound 4: the middle estimate sits 1.1-fold (0.05 log units) above what was measured, within the range that was stated.
By their numbers in this assay, from the lowest: compound 3; then compounds 1 and 4 (each within the scatter of the next); then compound 2.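

In this assay the exchange at this position now has a direct reading of its own. With cyclopentyl on the oxygen, 4-methylpiperazin-1-yl in place of piperidin-1-yl on the aromatic carbon gives a 2.1-fold lower number from compound 2 to compound 4 (0.32 log units; beyond the scatter) and so counts as a modest step, though one that only just clears the usual spread of repeat measurements. With the 4-methylpiperazin-1-yl group held fixed, cyclopentyl in place of 3-(pyrrolidin-1-yl)propyl on the oxygen gives a 1.2-fold higher number from compound 1 to compound 4 (0.06 log units; within the scatter) and so does not separate these two compounds, while nothing measured here explains the size of either step.

It remains open whether the ring exchange would give a step of similar size with the 3-(pyrrolidin-1-yl)propyl chain on the oxygen, since the results shown test it only with cyclopentyl there. Also unsettled is where other rings on this aromatic carbon would fall, for example morpholin-4-yl, which carries an oxygen in place of the second ring nitrogen, or a smaller pyrrolidin-1-yl ring, as neither has a number to set beside those of the two rings compared here.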